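Taking the nitro group off compound 2

The source may report more compounds than this note shows. Statements on the series, on what has been measured and on what is new or still open speak of the compounds shown alone.

In a functional assay on CCRF-CEM cells (Homo sapiens) for antiproliferative activity (on this read-out higher numbers stand for weaker inhibition and lower numbers for stronger inhibition), compound 1 `COc1cc(C(=O)c2sc(-c3ccc(Cl)cc3)cc2N)cc(OC)c1OC` gives 70 nM and compound 2 `COc1cc(C(=O)c2sc(-c3cccc([N+](=O)[O-])c3)cc2N)cc(OC)c1OC` gives 5.9 nM, the lower of the two numbers and therefore the stronger inhibition. Compound 3 `COc1cc(C(=O)c2sc(-c3ccccc3)cc2N)cc(OC)c1OC` has not yet been measured. It differs from compound 2 by one change, hydrogen in place of nitro on an aromatic carbon. This turns the 3-nitrophenyl into a plain phenyl on the shared core.

Within the data shown here, only one measured step bears on this change: a 12-fold lower number from compound 1 to compound 2 (1.07 log units; beyond the scatter). That step is large and lies beyond the scatter, so the group carried on this phenyl can shift the number considerably. However, it replaced one group with another at a different place on the ring, so it cannot show what the nitro does alone. Among the measured compounds shown here, no compound with a bare phenyl has been measured either. For the measured compounds named here, with compound 2 at the low end of the numbers so far, a rise in this assay is expected, of a size beyond the scatter. The expected step is a 6.8-fold higher number from compound 2 to compound 3 (0.83 log units; beyond the scatter). For compound 3 the estimated value is 40 nM, with an expected range from 10 nM to 150 nM.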

Compound 3, half-maximal inhibitory concentration: 4.5 nM
Compound 3: middle estimate off by 8.9-fold (0.95 log units), on the high side; measured number below the stated range.
By their numbers in this assay, from the lowest: compounds 3 and 2 (each within the scatter of the next); then compound 1.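

In this assay removing the nitro group gives a 1.3-fold lower number from compound 2 to compound 3 (0.12 log units; within the scatter) and so leaves the 3-nitrophenyl and the plain phenyl indistinguishable on this read-out, which means the nitro group is not needed for the low number of compound 2. Removing the chloro group from compound 1 gives a 16-fold lower number from compound 1 to compound 3 (1.19 log units; beyond the scatter) and this changes how the earlier large step reads: the gap between compound 1 and compound 2 now appears to come from the chloro group of compound 1 pushing the number up, not from the nitro group bringing it down. Why the chloro group has this large effect while the nitro group has none beyond the scatter is not explained by anything available here.

Open still is how much else the bare phenyl accepts at the place the nitro group held, for example an amine or a carboxylic acid, which would show whether this place tolerates groups in general or only some. Also open, going by these compounds, is whether a chloro group on that same place would raise the number as it does in compound 1, which would separate the effect of the group from the effect of where it sits on the ring.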